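A few compounds are considered here, and "the series" means these few. Any claim that something is new, unique, unknown or untested is made for them only; others in the source may bear on it.

Measured in a functional assay on Hs-578T cells (Homo sapiens) for inhibition, read by sulforhodamine B assay, with a stated time of 48 h; on this read-out higher numbers stand for weaker inhibition of growth and lower numbers for stronger inhibition of growth:
compound 1 `Nc1cc(N)c2nc(-c3ccccc3)c(NCc3ccc(Cl)c(Cl)c3)nc2c1` — 46800 nM.
compound 2 `COc1ccc(CNc2nc3cc(N)cc(N)c3nc2-c2ccccc2)cc1OC` — a limit only, < 100000 nM.

Compound 2 stands at a limit of this assay, so its place relative to compound 1 is not fixed. Going by the values given here, the only measured step, a step that the limit leaves unreadable from compound 1 to compound 2, is left unreadable by that same limit (the limit of < 100000 nM in this assay, at which 1 of the 2 values shown sits). Compound 3 `COc1cc(CNc2nc3cc(N)cc(N)c3nc2-c2ccccc2)cc(OC)c1OC` differs from compound 2 by methoxy in place of hydrogen on an aromatic carbon. Among the compounds with values here, no measured step concerns an added methoxy, and the one recorded step carries no size, so no direction beyond the scatter is expected for a step that the limit leaves unreadable from compound 2 to compound 3; the expectation rests only on where compound 2 sits. Compound 3 is therefore estimated at 60000 nM, within 20000 nM to 100000 nM, and a further limit-only result is likely.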

Compound 3, concentration for total growth inhibition: 33100 nM
Estimate against measurement, compound 3: 1.8-fold (0.26 log units) above; low and high end bracket the measured number.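

No step can be read from compound 2 to compound 3 in this assay, since the value of compound 2 is only a limit: the limit of < 100000 nM in this assay, at which 1 of the 3 values shown sits.

As far as these compounds go, what the added methoxy changes, and where compound 2 stands relative to compound 1, stay open.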